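Cytotoxicity of a Bromo-for-Fluoro Swap in a Quinoline Series

The compounds below may be only part of what the source reports. "The series", "measured", "known", "first", "only" and "open" are said of these compounds alone.

The set comprises four compounds built on a shared core. Compound 1 `Clc1ccc2c(NCCNc3nccc(Nc4ccccc4)n3)ccnc2c1` and compound 2 `Clc1ccc2c(NCCNc3nccc(Nc4ccc(Br)cc4)n3)ccnc2c1` were tested in an ADME assay on Vero cells (Chlorocebus sabaeus) for cytotoxicity, read by neutral red uptake, with a stated time of 72 h (a lower number here means a stronger inhibitor, a higher number a weaker inhibitor), and in each case no number was obtained. In this assay compound 1 returned "not active" (no number reported). In this assay compound 2 likewise returned "not active" (no number reported). Going by the values given here, compound 3 `Fc1ccc(Nc2ccnc(NCCCNc3ccnc4cc(Cl)ccc34)n2)cc1` is the only member for which a number exists, and in this assay compound 3 gives 13700 nM; it therefore stands alone among the numbers, with nothing to rank it against. Compound 4 `Clc1ccc2c(NCCCNc3nccc(Nc4ccc(Br)cc4)n3)ccnc2c1` remains to be measured. It differs from compound 3 in one place: bromo in place of fluoro on an aromatic carbon, para to a large group. Among the compounds with values here, no measured pair in the set shows what such a swap does in this assay, so the size of the step must be guessed. The expectation is for no movement beyond the scatter, with the step of a 1.0-fold higher number from compound 3 to compound 4 (0.01 log units; within the scatter) expected to be small. Compound 4 is expected to fall near 14000 nM, within a range from 5000 nM to 40000 nM.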

Compound 4, half-maximal inhibitory concentration: 11200 nM
Beside the measured number, compound 4's estimate is 1.3-fold (0.10 log units) above it; measured number inside the range.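

In this assay, going by these compounds alone, the change from 4-fluorophenyl to 4-bromophenyl forms the only pair in the set with a readable step, a 1.2-fold lower number from compound 3 to compound 4 (0.09 log units; within the scatter), so on this aromatic carbon, para to a large group, the two groups cannot be told apart. Compound 2 carries the same 4-bromophenyl group and differs from compound 4 in its chain, yet compound 2 returned "not active" (no number reported), so that step cannot be read, although compound 4 gives 11200 nM. Nothing available explains the result.

The compounds shown leave open how an amine or a carboxylic acid on the same aromatic carbon would read in this assay. Within the data shown here, they also leave open whether a longer chain than the one shared by compound 3 and compound 4 would still give a number.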